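The source may report more compounds than this note shows. Statements on the series, on what has been measured and on what is new or still open speak of the compounds shown alone.

Compound 1 (`COc1ccc(-c2cc(NC(=O)Nc3ccccn3)cc(OC)c2OC)cn1`): 32900 nM
Compound 2 (`COc1cc(NC(=O)Nc2ccncc2)cc(-c2cccnc2)c1OC`): 73600 nM
Compound 3 (`O=C(Nc1ccncc1)Nc1cc(-c2cccnc2)cc(C(F)(F)F)c1`): "not determined" (no result reported)

All three entries come from a functional assay on SMMC-7721 cells (Homo sapiens) for inhibition, read by MTT assay, with a stated time of 48 h; on this read-out lower numbers stand for stronger inhibition and higher numbers for weaker inhibition. Compound 3 has no number there, its result being "not determined" (no result reported), so it cannot be placed above or below the others. Compound 4 (`COc1ccc(-c2cc(NC(=O)Nc3ccncc3)cc(C(F)(F)F)c2)cn1`) is still to be measured. The structural change is methoxy in place of hydrogen on an aromatic carbon, which turns pyridin-3-yl into 6-methoxypyridin-3-yl. Going by the values given here, without a starting number for compound 3, the size of this step cannot be read directly, and no measured pair shows this change alone. The nearest hint is indirect: compound 1, which carries 6-methoxypyridin-3-yl, gives 32900 nM, while compound 2, which carries pyridin-3-yl, gives 73600 nM, but these two also differ in other places. A small step toward stronger inhibition is therefore expected, and possibly none beyond the usual scatter. For compound 4 the estimated value is 40000 nM, with an expected range of 12000 nM to 100000 nM.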

Compound 4, half-maximal inhibitory concentration: > 300000 nM
Compound 4: no number, only a limit; the forecaster's own chance of this, stated with the estimate: 15%; at least 7.5-fold (0.87 log units) between middle value and limit.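

No step can be read from compound 3 to compound 4, as compound 3 has no reported result and compound 4 has only a limit, not a number: the limit of > 300000 nM in this assay, at which 1 of the 4 values shown sits.

The compounds shown leave open how far methoxy in place of hydrogen, on its own, shifts inhibition in this assay.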